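Amide heteroaryl exchange on the shared core

The source may hold more compounds than are shown below. What is called first, only, known or untested is meant among the compounds shown, and "the series" means these compounds.

Compound 1 `CC(C)[C@H](C(=O)Nc1cccnn1)c1ccc(Cl)cc1` is the reference point of the series. Going by the values given here, in a functional assay on CHO cells for agonist activity at Free fatty acid receptor 2 (Homo sapiens), read by cAMP accumulation (a lower number here means a smaller maximal response, a higher number a larger maximal response), compound 1 gives 101%, the only numerical value shown so far. Compound 2 `CC(C)C(C(=O)Nc1nnn[nH]1)c1ccc(Cl)cc1` returns a limit of the assay rather than a number in this assay, < 30%. That limit is the one at which (the limit of < 30% in this assay, at which 1 of the 2 values shown sits). Among the compounds with values here, no step between two measured compounds that differ in one place is available, so the size of a change at the amide-bound ring is not measured here.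

Compound 3 `Cc1csc(NC(=O)[C@H](c2ccc(Cl)cc2)C(C)C)n1` is not yet measured. The change from compound 1 is 4-methyl-1,3-thiazol-2-yl in place of pyridazin-3-yl on an amide-type nitrogen. A step down in maximal response, small enough to lie within or only just beyond the scatter, is expected, a number 11 percentage points lower from compound 1 to compound 3 (beyond the scatter). The starting point for that expectation is compound 1 at 101%. For compound 3 the estimate in this assay is 90%, with a range from 55% to 110%.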

Compound 3, largest response reached (reported as efficacy), in percent of the reference or control that the assay uses: 87%
Beside the measured number, compound 3's estimate is 3 percentage points above it; the range from low to high includes it.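

This position now has a measured step: in this assay, 4-methyl-1,3-thiazol-2-yl in place of pyridazin-3-yl on an amide-type nitrogen gives a number 14 percentage points lower from compound 1 to compound 3 (beyond the scatter). A substantial maximal response at this position therefore does not require the six-membered pyridazin-3-yl ring, as a five-membered aromatic ring holding sulfur and bearing a methyl group retains most of it. Nothing measured in the series gives a cause for this step.

The compounds shown include no 1,3-thiazol-2-yl without the methyl group, so the ring exchange and the methyl group cannot be separated within the step. As far as these compounds go, how a phenyl ring on the same nitrogen would compare in this assay also remains open.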